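Phenyl to 4-methylphenyl on compound 3

The source may hold more compounds than are shown below. What is called first, only, known or untested is meant among the compounds shown, and "the series" means these compounds.

In a functional assay on the whole organism for inhibition, with Mus musculus as the target (a higher number here means that more compound is needed for the effect, a lower number that less compound is needed), three compounds share one core and differ in the chain on the amide-type nitrogen. Compound 1 `CCNC(=O)Nc1cccc2c1CN(C)CC2c1ccccc1` gives 54 mg/kg. Compound 2 `CCCNC(=O)Nc1cccc2c1CN(C)CC2c1ccccc1` reaches only a limit of the assay, > 80 mg/kg. Compound 3 `CCCCNC(=O)Nc1cccc2c1CN(C)CC2c1ccccc1`, with a butyl chain, gives 23 mg/kg, the lower of the two actual numbers.

The next compound, compound 4 `CCCCNC(=O)Nc1cccc2c1CN(C)CC2c1ccc(C)cc1`, keeps that chain and changes the aromatic ring instead: methyl in place of hydrogen on an aromatic carbon. This is methyl in place of hydrogen on an aromatic carbon, para to a large group, so phenyl becomes 4-methylphenyl.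

Among the compounds with values here, no measured step covers this place. All three measured steps lie in the chain, so they bear on the change only as a guide to size. They are an at least 1.4-fold higher number from compound 1 to compound 2 (0.17 log units; that floor lies within the scatter), a 2.3-fold lower number from compound 1 to compound 3 (0.37 log units; beyond the scatter) and an at least 3.4-fold lower number from compound 2 to compound 3 (0.54 log units; beyond the scatter). These small alkyl changes moved the number in both directions, and they give no direction for a ring methyl. A step of no more than modest size is therefore expected, with the direction open and only a slight allowance for a higher number.

The expected change is a 1.2-fold higher number from compound 3 to compound 4 (0.09 log units; within the scatter). For compound 4 the estimate is 28 mg/kg, with an expected range of 12 mg/kg to 65 mg/kg.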

Compound 4, dose for half-maximal effect: about 15 mg/kg
Compound 4: the middle estimate sits 1.9-fold (0.27 log units) above what was measured; measured number inside the range.
By their numbers in this assay, from the lowest: compounds 4 and 3 (each within the scatter of the next); then compound 1. At a limit, above all of these: compound 2.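

The place on the aromatic carbon, para to a large group, now has a measured step of its own in this assay: a 1.5-fold lower number from compound 3 to compound 4 (0.19 log units; within the scatter). Methyl in place of hydrogen at this place therefore leaves compound 4 within the scatter of compound 3, unlike the chain, where an at least 3.4-fold lower number from compound 2 to compound 3 (0.54 log units; beyond the scatter), so on this one change the ring place has shown no step beyond the scatter. Nothing shown gives a cause for this step.

From the compounds shown here alone, how far this reading carries beyond a single methyl remains open, since one small group at one place says nothing about a chloro, methoxy or trifluoromethyl group at the same place, or about a methyl elsewhere on that ring. The 4-methylphenyl group is also shown only together with the butyl chain, so whether the step would look the same with the ethyl chain of compound 1, or with a longer chain such as hexyl, cannot be said from these compounds.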